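Swapping a Furan Ring for Methoxy on a Shared Core

This account rests on a few compounds, and the source may have more. Where it says the series, first, only, none or still open, it means among the compounds named here.

Compound 2 `c1coc(-c2ncnc3[nH]cc(Sc4cccs4)c23)c1` is tested in a functional assay on CEM-DNR cells (Homo sapiens), read by MTT assay, with a stated time of 3 days (on this read-out lower numbers stand for stronger inhibition and higher numbers for weaker inhibition), where compound 2 gives 20800 nM. Compound 1 `CNc1ncnc2[nH]cc(Sc3cccs3)c12` carries methylamino instead of furan-2-yl, and compound 1 gives 26200 nM in this assay. Compound 2 holds the lower of these two numbers, yet the step of a 1.3-fold lower number from compound 1 to compound 2 (0.10 log units; within the scatter) sits within the scatter, so the two are indistinguishable. Compound 3 `COc1ncnc2[nH]cc(Sc3cccs3)c12` brings (methoxy in place of furan-2-yl on an aromatic carbon). Within the data shown here, the single step known here, from methylamino to furan-2-yl, barely moved the number, and nothing measured touches methoxy itself, so no shift beyond the scatter is expected. For compound 3 the estimate is 25000 nM, ranging from 10000 nM to 60000 nM, an expected step of a 1.2-fold higher number from compound 2 to compound 3 (0.08 log units; within the scatter).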

Compound 3, half-maximal inhibitory concentration: > 50000 nM
Compound 3 gave a limit, no number; the forecaster's own chance of this, stated with the estimate: 10%; at least 2.0-fold (0.30 log units) between middle value and limit.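

Compound 3 gives a limit, not a number: the limit of > 50000 nM in this assay, at which 1 of the 3 values shown sits.

Even so, in this assay the group on this aromatic carbon can matter, which the first pair could not show: methoxy in place of furan-2-yl gives an at least 2.4-fold higher number from compound 2 to compound 3 (0.38 log units; beyond the scatter), meaning weaker inhibition. Methoxy in place of methylamino gives an at least 1.9-fold higher number from compound 1 to compound 3 (0.28 log units; that floor lies within the scatter), so this floor alone does not separate those two groups.

On these data alone, it remains open whether ethoxy or a phenyl ring at this place would sit with compound 1 and compound 2 or with compound 3.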